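Methoxy in place of hydrogen on compound 1

The compounds below may be only part of what the source reports. "The series", "measured", "known", "first", "only" and "open" are said of these compounds alone.

The series rests on the shared core of compound 1, `CN1C/C(=C\c2ccccc2)C(=O)[C@]2(C1)[C@@H](c1ccccc1)CN(C)[C@@]21C(=O)Nc2ccccc21`. In a functional assay on the whole organism (strain Wister albino) for inhibition, with Rattus norvegicus as the target, read by paw edema, with stated times of 1 h and 4 h, at a dose of 50 mg/kg by the intraperitoneal route (a lower number here means less inhibition, a higher number more inhibition at the dose given (going by the name of the read-out)), compound 1 gives 70.9%. Compound 2, `CN1C/C(=C\c2ccccc2)C(=O)[C@]2(C1)[C@@H](c1ccccc1)CN(C)[C@@]21C(=O)N(C)c2ccccc21`, carries methyl in place of hydrogen on an amide-type nitrogen in a ring; in this assay compound 2 gives 68.8%. The step of a number 2.1 percentage points lower from compound 1 to compound 2 (within the scatter) stays within the scatter, so the two measured numbers stand together and neither compound can be set above the other.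

Compound 3, `COc1ccc(/C=C2\CN(C)C[C@@]3(C2=O)[C@@H](c2ccccc2)CN(C)[C@@]32C(=O)Nc3ccccc32)cc1`, differs from compound 1 at another place: methoxy in place of hydrogen on an aromatic carbon. Within the data shown here, no measured step bears on this change. Among the measured compounds shown here, the only step in hand, a number 2.1 percentage points lower from compound 1 to compound 2 (within the scatter), alters an amide-type nitrogen in a ring, not an aromatic carbon, and was itself within the scatter. For the measured compounds named here, the two measured numbers show only that one small change to the core left the read-out unmoved. Going by the values given here, with no supporting step, compound 3 is expected to move by a number 0.9 percentage points lower from compound 1 to compound 3 (within the scatter), that is, not beyond the scatter. Compound 3 is therefore estimated at 70% in this assay, within the range 58% to 80%.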

Compound 3, a percentage reported as inhibition, in the whole organism at one dose (the size of the read-out at that dose, not a potency): 78.7%
The estimate for compound 3 lay 8.7 percentage points below the measured number; measured number inside the range.
By their numbers in this assay, from the lowest: compounds 2, 1 and 3 (each within the scatter of the next).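

In this assay, among these compounds, the change from phenyl to 4-methoxyphenyl gives a number 7.8 percentage points higher from compound 1 to compound 3 (within the scatter) and so provides the first reading at this aromatic carbon, on a six-membered aromatic ring of carbon only and para to a large group. Methoxy at this place therefore leaves the read-out within the scatter, as methyl did on the amide-type nitrogen in the step of a number 2.1 percentage points lower from compound 1 to compound 2 (within the scatter) at a different place on the shared core. Two single changes at two separate places now leave the percentage inhibition at this one dose within the scatter, but no available measurement gives a reason for the size of the methoxy step.

Going by these compounds, it remains open whether a different group at the same aromatic carbon, such as chlorine, an amine, a carboxylic acid or a longer chain like butoxy, would give a step beyond the scatter. Also open, on these data alone, is how methoxy at this place and methyl on the amide-type nitrogen would read together on the shared core.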